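Chain on the aromatic nitrogen: methyl to isopentyl

A few compounds are considered here, and "the series" means these few. Any claim that something is new, unique, unknown or untested is made for them only; others in the source may bear on it.

In a functional assay on LNCaP cells (Homo sapiens) for inhibition, read by WST assay, with a stated time of 3 days (on this read-out lower numbers stand for stronger inhibition and higher numbers for weaker inhibition), the measured compounds read:
- compound 1 `Cn1ccnc1/C=C/C(=O)/C=C/c1coc2ccccc2c1=O` gives 2300 nM
- compound 2 `CCn1ccnc1/C=C/C(=O)/C=C/c1coc2ccccc2c1=O` gives 1000 nM
- compound 3 `CCC(C)n1ccnc1/C=C/C(=O)/C=C/c1coc2ccccc2c1=O` gives 1300 nM

Compound 1 at 2300 nM holds the highest of the three numbers, though only its step to compound 2 lies beyond the scatter. Compound 4 `CC(C)CCn1ccnc1/C=C/C(=O)/C=C/c1coc2ccccc2c1=O` has not yet been measured. The change is isobutyl in place of hydrogen on a saturated chain carbon bound to an aromatic nitrogen and, cut one bond further out, reads methyl to isopentyl. Among the compounds with values here, three measured steps bear on it: a 2.3-fold lower number from compound 1 to compound 2 (0.36 log units; beyond the scatter) and a 1.8-fold lower number from compound 1 to compound 3 (0.25 log units; within the scatter) are both small, and a 1.3-fold higher number from compound 2 to compound 3 (0.11 log units; within the scatter) stays within the scatter. Within the data shown here, no measured compound carries the isopentyl chain itself. Resting on compound 2 at 1000 nM and compound 3 at 1300 nM, a similar small lowering from compound 1 is expected, with no further gain from the longer chain. The step expected in this assay is a 1.9-fold lower number from compound 1 to compound 4 (0.28 log units; within the scatter) as an estimate. Compound 4 is expected at 1200 nM within an estimated range of 550 nM to 2600 nM on this reasoning.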

Compound 4, half-maximal inhibitory concentration: 4000 nM
For compound 4 the middle estimate is 3.3-fold (0.52 log units) below the measured one; measured number outside the range, above it.
By their numbers in this assay, from the lowest: compounds 2, 3, 1 and 4 (each within the scatter of the next, the first and the last beyond it).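

In this assay the chain on the aromatic nitrogen proves sensitive to its form: a 3.1-fold higher number from compound 3 to compound 4 (0.49 log units; beyond the scatter) and a 4.0-fold higher number from compound 2 to compound 4 (0.60 log units; beyond the scatter) both lie beyond the scatter, a difference the three earlier compounds did not reveal. The number does not follow chain length in one direction, since a 1.7-fold higher number from compound 1 to compound 4 (0.24 log units; within the scatter) stays within the scatter, so the methyl and isopentyl compounds cannot be ordered even though the ethyl and sec-butyl compounds between them in size do not read higher than compound 4. No evidence at hand accounts for the higher number carried by the isopentyl chain.

Open, going by these compounds, is whether the higher number belongs to chain length or to the branch at its far end, which a straight n-butyl or n-pentyl chain would separate. Also open, on these data alone, is how a benzyl group, or a chain ending in an amine or a carboxylic acid, would read at this position.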